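The source may hold more compounds than are shown below. What is called first, only, known or untested is meant among the compounds shown, and "the series" means these compounds.

In a functional assay on L1210 cells (Mus musculus) for inhibition (on this read-out lower numbers stand for stronger inhibition and higher numbers for weaker inhibition), three compounds sharing one core have numbers: compound 1 `CCCCC#Cc1c(C(N)=O)ncn1C1O[C@H](CO)[C@@H](O)[C@H]1O` gives 2.29 ug/mL, compound 3 `CC(C)(O)C#Cc1c(C(N)=O)ncn1C1O[C@H](CO)[C@@H](O)[C@H]1O` gives 4.8 ug/mL, and compound 2 `NC(=O)c1ncn(C2O[C@H](CO)[C@@H](O)[C@H]2O)c1C#Cc1ccccc1` gives 20.6 ug/mL, the highest of the three. Compound 4 `N#Cc1ncn(C2O[C@H](CO)[C@@H](O)[C@H]2O)c1C#Cc1ccccc1` keeps the 2-phenylethynyl group of compound 2 but carries cyano in place of carbamoyl on an aromatic carbon. The measured steps, a 9.0-fold higher number from compound 1 to compound 2 (0.95 log units; beyond the scatter), a 2.1-fold higher number from compound 1 to compound 3 (0.32 log units; beyond the scatter) and a 4.3-fold lower number from compound 2 to compound 3 (0.63 log units; beyond the scatter), all alter the group on the triple bond, so none tests this exchange. They only indicate how far numbers move in this set, and the direction remains a judgement. A modest step toward weaker inhibition is expected, a 1.9-fold higher number from compound 2 to compound 4 (0.29 log units; within the scatter). For compound 4 the estimated value is 40 ug/mL, with an expected range of 12 ug/mL to 100 ug/mL.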

Compound 4, half-maximal inhibitory concentration: 80.3 ug/mL
Beside the measured number, compound 4's estimate is 2.0-fold (0.30 log units) below it; the measured number falls inside the stated range.
By their numbers in this assay, from the lowest: compound 1; then compound 3; then compound 2; then compound 4.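

In this assay, the exchange at this ring carbon gives a 3.9-fold higher number from compound 2 to compound 4 (0.59 log units; beyond the scatter) and so moves the number beyond the scatter, showing that this position, not only the group on the triple bond, bears on inhibition. The exchange removes the hydrogen-bond donor of carbamoyl, but nothing shown here separates that loss from any other difference between the two groups or explains the rise.

The exchange is shown only with the 2-phenylethynyl group, so its size with butyl or 1-hydroxy-1-methylethyl on the triple bond remains open. Going by these compounds, how a carboxylic acid or a methyl ester would compare at this position also remains open.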